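Methoxy to hydroxy on the aryl group of compound 1

The source may hold more compounds than are shown below. What is called first, only, known or untested is meant among the compounds shown, and "the series" means these compounds.

In a functional assay on MCF7 cells (Homo sapiens) for cytotoxicity, read by MTT assay, in the absence of a further agent (on this read-out higher numbers stand for an effect only at larger amounts of compound and lower numbers for an effect already at smaller amounts), compound 1 `COc1cc(O)ccc1-c1oc2cc(OC)c(CC=C(C)C)c(O)c2c1C=O` gives 6700 nM, and compound 2 `COc1cc(O)ccc1-c1oc2cc(OC)c(CCC(C)(C)O)c(O)c2c1C=O` gives 4800 nM. Among the measured compounds shown here, these are the only two numbers so far. For the measured compounds named here, the single measured step is a 1.4-fold lower number from compound 1 to compound 2 (0.14 log units; within the scatter), so compound 1 has no rank of its own and sits level with compound 2.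

Compound 3 `COc1cc2oc(-c3ccc(O)cc3O)c(C=O)c2c(O)c1CC=C(C)C` keeps the core and the side chain of compound 1, and it carries hydrogen in place of methyl on an oxygen on an aromatic ring, which reads as 4-hydroxy-2-methoxyphenyl to 2,4-dihydroxyphenyl: hydrogen in place of methyl on an oxygen on an aromatic ring.

Going by the values given here, no measured pair covers this change. Among the compounds with values here, the step to compound 2 bears on it only loosely, as it concerns the chain and not this oxygen, and it shows only that one change elsewhere on the shared core stayed within the scatter. With so little evidence, the range must stay wide. The step expected in this assay is none beyond the scatter, estimated as a 1.1-fold lower number from compound 1 to compound 3 (0.05 log units; within the scatter). Compound 3 is expected at 6000 nM, within an estimated range of 2000 nM to 18000 nM.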

Compound 3, half-maximal effective concentration: 2600 nM
Compound 3: middle estimate off by 2.3-fold (0.36 log units), on the high side, and the stated range covers the measured number.
By their numbers in this assay, from the lowest: compounds 3, 2 and 1 (each within the scatter of the next, the first and the last beyond it).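

In this assay, among the compounds shown here, hydrogen in place of methyl on an oxygen on an aromatic ring gives a 2.6-fold lower number from compound 1 to compound 3 (0.41 log units; beyond the scatter) and is the first single change to lie beyond the scatter, though only modestly. For the compounds shown here, the step on the chain, a 1.4-fold lower number from compound 1 to compound 2 (0.14 log units; within the scatter), did not separate its two compounds, so methoxy to hydroxy on the aryl group is the first change on the shared core that moves the number in a readable way. No measured property of these compounds bears on this step, and the data offer no explanation for it.

Methoxy to hydroxy has been read on only one background, with the 2-methylprop-1-en-1-yl end of the chain, so whether a similar step appears with the 2-hydroxy-2-methylpropyl chain of compound 2 remains open. The compounds shown also leave open how other groups would read at this oxygen or in its place on the aryl group, for example ethyl, a longer chain, a carboxylic acid or an amine, since only methyl and hydrogen on that oxygen are covered here.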